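Hydroxycarbamoyl chain extension from compound 2 to compound 3

This account rests on a few compounds, and the source may have more. Where it says the series, first, only, none or still open, it means among the compounds named here.

Measured in a functional assay on ES2 cells (Homo sapiens) for inhibition, read by MTT assay, with a stated time of 48 h; a lower number here means a stronger inhibitor, a higher number a weaker inhibitor:
- compound 1 `O=S(=O)(c1ccccc1)c1c(OCCCCCCO)no[n+]1[O-]` gives "not determined" (no result reported)
- compound 2 `O=C(CCCCCCOc1no[n+]([O-])c1S(=O)(=O)c1ccccc1)NO` gives 7730 nM

Within the data shown here, compound 2 holds the only number, so it has no ranking. Compound 3 `O=C(CCCCCCCOc1no[n+]([O-])c1S(=O)(=O)c1ccccc1)NO`, not yet measured, differs from it by (hydroxycarbamoyl)methyl in place of hydroxycarbamoyl on a saturated chain carbon, six bonds along the chain from an oxygen on an aromatic ring, that is, (hydroxycarbamoyl)methyl in place of hydroxycarbamoyl on a saturated chain carbon. Among the measured compounds shown here, no measured pair shows what such a change does in this assay, so only a small step toward stronger inhibition is expected, hardly beyond the scatter. The estimated change is a 1.4-fold lower number from compound 2 to compound 3 (0.15 log units; within the scatter) in this read-out. Compound 3 is expected at 5500 nM (estimated range 2000 nM to 15000 nM).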

Compound 3, half-maximal inhibitory concentration: 1320 nM
Compound 3: middle estimate off by 4.2-fold (0.62 log units), on the high side; the whole stated range lies above it.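

In this assay, (hydroxycarbamoyl)methyl in place of hydroxycarbamoyl on this saturated chain carbon gives a 5.9-fold lower number from compound 2 to compound 3 (0.77 log units; beyond the scatter). Among these compounds, this is the first reading at this position, and it shows that the number responds to this one-carbon change by a step beyond the scatter. Nothing on hand gives a reason for the step. Still open, going by these compounds, is whether 2-(hydroxycarbamoyl)ethyl, a longer chain again, lowers the number further or reverses the step. Also open, on these data alone, is what a carboxylic acid in place of the hydroxycarbamoyl end would give.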